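A few compounds are considered here, and "the series" means these few. Any claim that something is new, unique, unknown or untested is made for them only; others in the source may bear on it.

In an ADME assay on HepG2 2.2.15 cells (Homo sapiens) for cytotoxicity (on this read-out higher numbers stand for lower toxicity in this test and lower numbers for higher toxicity in this test), compound 3 `CCCCCCCC(=O)OCCc1c(-c2ccccc2Cl)c2cc(Cl)ccc2[nH]c1=O` gives 78000 nM, and compound 1 `C=CCn1c(=O)c(CCO)c(-c2ccccc2Cl)c2cc(Cl)ccc21` gives 23000 nM, so compound 3 holds the higher of the two actual numbers, by a gap beyond the usual scatter. Compound 2 `O=c1c(CCO)c(-c2ccccc2Cl)c2cc(Cl)ccc2n1-c1c(F)cccc1F` gives only a limit of the assay, > 2300000 nM.

The next compound, compound 4 `O=C(OCCc1c(-c2ccccc2Cl)c2cc(Cl)ccc2[nH]c1=O)C1CCCC1`, differs from compound 3 in one place: cyclopentyl in place of heptyl on a carbonyl carbon. Put simply, this is cyclopentyl in place of heptyl on a carbonyl carbon.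

Among the compounds with values here, the only measured step between two compounds differing in one place is an at least 100-fold higher number from compound 1 to compound 2 (2.00 log units; beyond the scatter). It is large, but it is 2,6-difluorophenyl in place of allyl on an aromatic nitrogen, a different place from the one changed here, so its size does not carry over. Within the data shown here, no measured step covers a change on the carbonyl carbon, so no shift beyond the scatter is expected in this assay.

The estimated step is small: a 1.2-fold higher number from compound 3 to compound 4 (0.06 log units; within the scatter). For compound 4 the expected value is 90000 nM, with an estimated range from 30000 nM to 270000 nM.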

Compound 4, half-maximal cytotoxic concentration: 46000 nM
Compound 4: middle estimate off by 2.0-fold (0.29 log units), on the high side; measured number inside the range.
By their numbers in this assay, from the lowest: compounds 1, 4 and 3 (each within the scatter of the next, the first and the last beyond it). At a limit, above all of these: compound 2.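

On the carbonyl carbon, cyclopentyl in place of heptyl gives a 1.7-fold lower number from compound 3 to compound 4 (0.23 log units; within the scatter) in this assay. Within the data shown here, this is the first measured change at this place, and it shows that replacing an open chain of 7 carbons with a five-membered ring of 5 carbons leaves the two compounds indistinguishable in this test. Nothing measured here gives a reason for this step.

On these data alone, the two groups compared at this place are both made of carbon only, so it remains open whether a group of another kind on the same carbonyl carbon, such as an amine or a chain ending in a carboxylic acid, would move the number beyond the scatter. As far as these compounds go, it is equally open how a much smaller group such as methyl, or a flat ring such as phenyl, would read there.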